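This account rests on a few compounds, and the source may have more. Where it says the series, first, only, none or still open, it means among the compounds named here.

Measured so far:
- compound 1, `O=C(/C=C/c1ccc(O)c(O)c1)c1cc2ccoc2cc1O`: 62.7%
- compound 2, `COc1ccc(/C=C/C(=O)c2cc3ccoc3cc2O)cc1`: 48.9%

Both compounds were tested in an assay on isolated protein for inhibition of lysosomal alpha-glucosidase (Rattus norvegicus), read by spectrophotometry, with a stated time of 5 min, tested at 25 ug/mL; on this read-out lower numbers stand for less inhibition and higher numbers for more inhibition at the one concentration tested (going by the name of the read-out). On this read-out compound 1 gives 62.7%, and compound 2 gives 48.9%, the lowest of the two numbers; the gap to compound 1 is beyond the usual scatter, so the inhibition in this assay is lower for compound 2 than for compound 1.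

The next compound, compound 3, `O=C(/C=C/c1ccc(O)cc1)c1cc2ccoc2cc1O`, has not yet been measured in this assay. It differs from compound 2 in one place:

hydrogen in place of methyl on an oxygen on an aromatic ring

Among the compounds with values here, no measured pair shows this exact change, so its effect has to be guessed. Compound 2 sits at the low end, and compound 1, which carries hydroxy groups rather than methoxy, sits higher, so a modest rise is expected for compound 3, roughly a number 6.1 percentage points higher from compound 2 to compound 3 (within the scatter), which may not clear the scatter. Compound 3 is therefore estimated at 55%, with a range from 42% to 68%.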

Compound 3, a percentage reported as inhibition, at one concentration (the size of the read-out at that concentration, not a potency): 8.77%
Compound 3: the middle estimate sits 46.2 percentage points above what was measured, outside the stated range (below it).
By their numbers in this assay, from the lowest: compound 3; then compound 2; then compound 1.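

In this assay, hydroxy in place of methoxy on this aromatic ring brings a number 40.1 percentage points lower from compound 2 to compound 3 (beyond the scatter), so this one small change on the oxygen can decide much of the inhibition seen at the single concentration tested. Removing a hydroxy from an aromatic carbon gives a number 53.9 percentage points lower from compound 1 to compound 3 (beyond the scatter), which shows that the extra hydroxy of compound 1 also counts heavily in this series. Nothing available explains why either change has so large an effect.

As far as these compounds go, it remains open whether a longer chain on that oxygen, such as ethoxy, would keep or raise the inhibition seen with methoxy, and whether an amine or a carboxylic acid could stand in for the hydroxy. Because each compound was read at one concentration, these numbers also leave their potencies open.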